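Replacing 3,4-dichlorophenyl with 4-methoxyphenyl at the assay limit

The source may report more compounds than this note shows. Statements on the series, on what has been measured and on what is new or still open speak of the compounds shown alone.

In an ADME assay on H9c2 cells (Rattus norvegicus) for cytotoxicity, read by resazurin assay, with a stated time of 72 h (on this read-out higher numbers stand for lower toxicity in this test and lower numbers for higher toxicity in this test), compound 3 `C/C(=N\Nc1nc(-c2ccc(Cl)c(Cl)c2)cs1)c1ccc(Cl)c(Cl)c1` gives > 50000 nM, which is a limit of the assay and not a number. Compound 1 `C/C(=N\Nc1nc(-c2ccccc2)cs1)c1ccc(Cl)c(Cl)c1` gives > 50000 nM, which is also a limit. Compound 2 `C/C(=N\Nc1nc(-c2ccncc2)cs1)c1ccc(Cl)c(Cl)c1` gives 41900 nM.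

Compound 4 `COc1ccc(-c2csc(N/N=C(\C)c3ccc(Cl)c(Cl)c3)n2)cc1` keeps the shared core and carries 4-methoxyphenyl in place of 3,4-dichlorophenyl on an aromatic carbon.

Three measured swaps on this same aromatic carbon bear on the change. They are an at least 1.1-fold lower number from compound 1 to compound 2 (0.07 log units; that floor lies within the scatter), an at least 1.1-fold higher number from compound 2 to compound 3 (0.07 log units; that floor lies within the scatter) and a step that the two limits leave unreadable from compound 1 to compound 3. These steps can be read only as floors or not at all because of the limit of > 50000 nM in this assay, at which 2 of the 3 values shown sit. Both floors lie within the scatter, so no step beyond the scatter is expected in this assay, although a small drop remains possible. The estimate amounts to an expected at least 1.1-fold lower number from compound 3 to compound 4 (0.04 log units; that floor lies within the scatter). Compound 4 is expected at 45000 nM, with an estimated range from 22000 nM to 70000 nM.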

Compound 4, half-maximal cytotoxic concentration: > 50000 nM
Compound 4 gave a limit, no number; the forecaster's own chance of this, stated with the estimate: 55%; middle value at least 1.1-fold (0.04 log units) from the limit.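

In this assay, the value of compound 4 is a limit and not a number, so this aromatic carbon also takes 4-methoxyphenyl, with one hydrogen-bond acceptor where 3,4-dichlorophenyl has none, without a readable value appearing. Within the data shown here, the one step that can be read is an at least 1.1-fold higher number from compound 2 to compound 4 (0.07 log units; that floor lies within the scatter), so it shows no change beyond the scatter. The steps to compound 4 from compound 1 and from compound 3 cannot be read, because of one shared ceiling: the limit of > 50000 nM in this assay, at which 3 of the 4 values shown sit.

From the compounds shown here alone, how far compound 1, compound 3 and compound 4 lie past that limit, and whether they differ from one another, stays open. Also open, going by these compounds, is whether an amine, a carboxylic acid or a longer chain at this carbon, in place of 4-methoxyphenyl, would give a value clearly lower than these.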